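A few compounds are considered here, and "the series" means these few. Any claim that something is new, unique, unknown or untested is made for them only; others in the source may bear on it.

In an ADME assay on the whole organism (Rattus norvegicus, strain Sprague-Dawley) for pharmacokinetics, read by LC-MS (on this read-out higher numbers stand for higher oral bioavailability and lower numbers for lower oral bioavailability), compound 3 (`N#Cc1ccc(O[C@H]2CN(S(=O)(=O)c3ccccc3C#N)C[C@@]2(O)CO)cc1F`) gives 32%. Compound 1 (`N#Cc1ccc(O[C@H]2CN(S(=O)(=O)c3ccc(Cl)cc3Cl)C[C@@]2(O)CN)cc1F`) gives 24%, within the scatter of compound 3, while compound 2 (`N#Cc1ccc(O[C@H]2CN(S(=O)(=O)c3ccc(Cl)cc3Cl)C[C@]2(O)CO)cc1F`) gives 100%, well beyond the scatter and clearly higher than compound 3.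

The next compound to be read is compound 4 (`N#Cc1ccc(O[C@H]2CN(S(=O)(=O)c3ccc(C(F)(F)F)nc3)C[C@@]2(O)CO)cc1F`), with 6-(trifluoromethyl)pyridin-3-yl in place of 2-cyanophenyl on a sulfonyl sulfur. The rest of the structure stays the same.

For the measured compounds named here, no measured pair differs in one place only, so this step has no direct precedent. Compound 2 at 100% and compound 1 at 24% carry the same group on the sulfonyl sulfur, so that group alone does not fix the number in this assay. Compound 3 at 32% leaves much open room on the scale up to compound 2, and a wide range is therefore warranted.

An upward move is expected, though with low confidence, and the estimated step is a number 16 percentage points higher from compound 3 to compound 4 (beyond the scatter), only modestly beyond the scatter. For compound 4 the expected value is 48%, with an estimated range of 22% to 80%.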

Compound 4, oral bioavailability: 100%
The estimate for compound 4 lay 52 percentage points below the measured number; measured number above the stated range.
By their numbers in this assay, from the lowest: compounds 1 and 3 (each within the scatter of the next); then compounds 2 and 4 (each within the scatter of the next).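

In this assay the change to 6-(trifluoromethyl)pyridin-3-yl in place of 2-cyanophenyl on a sulfonyl sulfur gives a number 68 percentage points higher from compound 3 to compound 4 (beyond the scatter) with the rest of the structure the same. For the compounds shown here, this is the first pair that differs in one place only, and it shows that the group on the sulfonyl sulfur can by itself move this read-out over a wide stretch of the scale, which the earlier compounds could not show. Nothing measured here explains the step, and it stays unassigned among the ring nitrogen, the trifluoromethyl group and the loss of the nitrile.

No pair shown separates these parts, so a phenyl ring carrying trifluoromethyl or a pyridine ring carrying a methoxy group would be needed to tell them apart. Also open, on these data alone, is whether the same exchange has a comparable effect in the presence of the amine of compound 1, and how a carboxylic acid on the ring attached to the sulfonyl sulfur would read in this assay.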